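The source may report more compounds than this note shows. Statements on the series, on what has been measured and on what is new or still open speak of the compounds shown alone.

Measured so far:
Compound 1 `CCCCn1c(-c2ccc(OC)cc2)cnc1NC(=O)c1ccc(F)cc1` gives > 100000 nM in a toxicity assay on THP-1 cells (Homo sapiens) for inhibition (on this read-out lower numbers stand for higher toxicity in this test and higher numbers for lower toxicity in this test), and this is a limit of the assay rather than a number.
Compound 2 `COc1ccc(-c2ccnc(NC(=O)c3ccc(F)cc3)c2)cc1` gives > 100000 nM in this assay, likewise a limit of the assay.
Compound 3 `Cc1ccc(C(=O)Nc2ncc(-c3ccccc3)o2)cc1` gives 26000 nM in this assay.

Compound 1 therefore stands at the limit of > 100000 nM in this assay, at which 2 of the 3 values shown sit, shared with compound 2, while compound 3 is the only one of the three with a measured number. Within the data shown here, no step between two measured compounds differing in a single place is available, so nothing measured bears directly on the change at hand.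

Compound 4 `CCn1c(-c2ccc(OC)cc2)cnc1NC(=O)c1ccc(F)cc1` differs from compound 1 by hydrogen in place of ethyl on a saturated chain carbon, two bonds along the chain from an aromatic nitrogen. The butyl of compound 1 thus shortens to an ethyl, with the rest of the molecule kept as it is.

The step from compound 1 to compound 4 is expected to be none beyond the usual scatter of this assay, a step that the limit leaves unreadable from compound 1 to compound 4, since nothing measured points in either direction. Compound 4 is expected to give about 150000 nM in this assay, within a range from 50000 nM to 500000 nM, and most likely the result will again be reported only as a limit.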

Compound 4, half-maximal cytotoxic concentration: > 100000 nM
Compound 4 gave a limit, no number; the forecaster's own chance of this, stated with the estimate: 75%; the middle value does not contradict the limit.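

Compound 1 and compound 4 both end at a limit of the assay, so no step between them can be read in this assay: the limit of > 100000 nM in this assay, at which 3 of the 4 values shown sit.

The compounds shown leave open whether going from butyl to ethyl changes the result in this assay at all.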